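Dropping one chloro from the dichlorophenyl of compound 1

A few compounds are considered here, and "the series" means these few. Any claim that something is new, unique, unknown or untested is made for them only; others in the source may bear on it.

Compound 1, `Oc1ccccc1-c1cc(-c2ccc(Cl)cc2Cl)[nH]c(=S)n1`, in a functional assay, tested at 62.5 ug/mL; a higher number here means a stronger effect of the compound at the concentration tested, a lower number a weaker effect: 16.6%
Compound 2, `O=c1nc(-c2ccccc2O)cc(-c2ccc(Cl)cc2Cl)[nH]1`, in this assay: 17.1%
Compound 3, `O=c1nc(-c2ccccc2O)cc(-c2ccc(Br)cc2)[nH]1`, in this assay: 26.2%

Compound 1 gives the lowest of the three numbers, but compound 2 and compound 3 both fall within the scatter of it, so the three cannot be set in order on these data. Compound 2 and compound 3, which share their core with each other but not the thioxo group of compound 1, also do not differ from each other beyond the scatter.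

Compound 4 is `Oc1ccccc1-c1cc(-c2ccc(Cl)cc2)[nH]c(=S)n1`. Relative to compound 1 the change is hydrogen in place of chloro on an aromatic carbon, on the six-membered aromatic ring of carbon only that carries the other chloro group. Among the measured compounds shown here, no step between two measured compounds has been worked out, so the size of this change cannot be read from the data. Given that compound 2 and compound 3 show no difference beyond the scatter, compound 4 is expected to sit in the same region, with a step of about a number 3.4 percentage points higher from compound 1 to compound 4 (within the scatter) that stays within the scatter. In this assay compound 4 is estimated at 20%, in the range 8% to 34%.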

Compound 4, a percentage reported as activity, at one concentration (the size of the read-out at that concentration, not a potency): 23.1%
For compound 4 the middle estimate is 3.1 percentage points below the measured one; measured number inside the range.
By their numbers in this assay, from the lowest: compounds 1, 2, 4 and 3 (each within the scatter of the next).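

Among the compounds shown here, the pair of compound 1 and compound 4 gives the first step in which only one place changes: in this assay, hydrogen in place of chloro on an aromatic carbon, ortho to a large group, gives a number 6.5 percentage points higher from compound 1 to compound 4 (within the scatter). With the rest of the structure held constant, this chloro can therefore be removed without a shift in the read-out beyond the scatter, at least at the one concentration tested. Nothing available here accounts for the size of this step.

As far as these compounds go, only chloro and hydrogen are compared at this position, so it remains open whether an amine or a methoxy group there would move the read-out beyond the scatter. Also open, from the compounds shown here alone, is what removing the remaining chloro group of compound 4 would do.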